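The source may report more compounds than this note shows. Statements on the series, on what has been measured and on what is new or still open speak of the compounds shown alone.

In an assay on brain for displacement of a labelled ligand from D(3) dopamine receptor (Rattus norvegicus) (a higher number here means a weaker inhibitor, a lower number a stronger inhibitor), compound 1 `CCCN(CC[C@H]1CC[C@H](NC(=O)/C=C/c2ccccc2Cl)CC1)[C@H]1CCc2nc(N)sc2C1` gives 1.2 nM, the lowest number among the three measured compounds. Compound 3 `CCCN(CC[C@H]1CC[C@H](NC(=O)c2ccc(-n3ccnc3)cc2)CC1)[C@H]1CCc2nc(N)sc2C1` gives 1.9 nM, and compound 2 `CCCN(CC[C@H]1CC[C@H](NC(=O)/C=C/c2ccccc2OC)CC1)[C@H]1CCc2nc(N)sc2C1` gives 8.1 nM. The change leading to compound 4 `CCCN(CC[C@H]1CC[C@H](NC(=O)c2cccc(-n3cncn3)c2)CC1)[C@H]1CCc2nc(N)sc2C1` is 3-(1H-1,2,4-triazol-1-yl)phenyl in place of 2-(2-chlorophenyl)ethenyl on a carbonyl carbon. The step that bears most closely on it put 4-(1H-imidazol-1-yl)phenyl in place of the same departing group and was small: a 1.6-fold higher number from compound 1 to compound 3 (0.20 log units; within the scatter). The other steps, a 6.8-fold higher number from compound 1 to compound 2 (0.83 log units; beyond the scatter) and a 4.3-fold lower number from compound 2 to compound 3 (0.63 log units; beyond the scatter), involve the methoxy compound and say less about the new group. A step no larger than the scatter is therefore expected, a 2.1-fold higher number from compound 1 to compound 4 (0.32 log units; beyond the scatter). Compound 4 is estimated at 2.5 nM, with a range from 1 nM to 7 nM.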

Compound 4, inhibition constant: 3 nM
For compound 4 the middle estimate is 1.2-fold (0.08 log units) below the measured one; low and high end bracket the measured number.
By their numbers in this assay, from the lowest: compounds 1, 3 and 4 (each within the scatter of the next, the first and the last beyond it); then compound 2.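

On this carbonyl carbon, 3-(1H-1,2,4-triazol-1-yl)phenyl gives a second case of a group with a five-membered aromatic ring replacing the ethenyl groups, with a 2.5-fold higher number from compound 1 to compound 4 (0.40 log units; beyond the scatter) and a 2.7-fold lower number from compound 2 to compound 4 (0.43 log units; beyond the scatter) in this assay. Against 4-(1H-imidazol-1-yl)phenyl there is a 1.6-fold higher number from compound 3 to compound 4 (0.20 log units; within the scatter), so this assay does not separate these two groups. Nothing available explains any of these differences. Going by these compounds, how a plain phenyl, or a phenyl carrying an amine or a carboxylic acid, would behave on this carbonyl carbon remains open.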